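This account rests on a few compounds, and the source may have more. Where it says the series, first, only, none or still open, it means among the compounds named here.

Of the compounds shown here, three sharing one core have been measured in a functional assay on MCF7 cells (Homo sapiens) for inhibition, read by MTT assay, with a stated time of 72 h; on this read-out lower numbers stand for stronger inhibition and higher numbers for weaker inhibition. There, compound 1 (`Clc1ccc(-c2nnc(SCCCN3CCN(c4nc5ccccc5o4)CC3)o2)cc1`) gives 99700 nM, compound 2 (`Brc1ccc(-c2nnc(SCCCN3CCN(c4nc5ccccc5o4)CC3)o2)cc1`) gives 115000 nM, and compound 3 (`Clc1ccc(-c2nnc(SCCCN3CCN(c4nc5ccccc5s4)CC3)o2)cc1`) gives 116000 nM. Compound 3 therefore stands level with the other two, as all three numbers lie within the scatter of one another.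

The step of interest leads to compound 4 (`O=C(NCc1nnc(SCCCN2CCN(c3nc4ccccc4s3)CC2)o1)c1ccccc1`), which has benzamidomethyl in place of 4-chlorophenyl on an aromatic carbon of a five-membered aromatic ring with 2 nitrogen and 1 oxygen: benzamidomethyl in place of 4-chlorophenyl on an aromatic carbon.

Within the data shown here, two measured steps bear on this only indirectly. Bromo in place of chloro changes the group that now leaves, and it gives a 1.2-fold higher number from compound 1 to compound 2 (0.06 log units; within the scatter). Replacing 1,3-benzoxazol-2-yl with 1,3-benzothiazol-2-yl changes another part of the structure, and it gives a 1.2-fold higher number from compound 1 to compound 3 (0.07 log units; within the scatter). Both steps are small, but neither replaces the whole aromatic substituent, so the data hold no direct measure of a change this large. No step beyond the scatter is therefore expected in this assay, though with wide uncertainty and no firm direction. The expected step is a 1.2-fold lower number from compound 3 to compound 4 (0.06 log units; within the scatter). Compound 4 is estimated at 100000 nM, with an expected range from 35000 nM to 280000 nM.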

Compound 4, half-maximal inhibitory concentration: 39000 nM
Beside the measured number, compound 4's estimate is 2.6-fold (0.41 log units) above it; the measured number falls inside the stated range.
By their numbers in this assay, from the lowest: compound 4; then compounds 1, 2 and 3 (each within the scatter of the next).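

In this assay, benzamidomethyl in place of 4-chlorophenyl on an aromatic carbon gives a 3.0-fold lower number from compound 3 to compound 4 (0.47 log units; beyond the scatter), the only step shown that lies beyond the scatter, and a modest one. The earlier steps shown here, a 1.2-fold higher number from compound 1 to compound 2 (0.06 log units; within the scatter) and a 1.2-fold higher number from compound 1 to compound 3 (0.07 log units; within the scatter), showed only that exchanging the halogen or the 1,3-benzoxazol-2-yl group left the number within the scatter, whereas this result shows that replacing the whole substituent at this position can move it towards stronger inhibition. The entering group keeps a six-membered aromatic ring of carbon only but also brings a hydrogen-bond donor and a hydrogen-bond acceptor, and no measurement available here shows which part of this change accounts for the shift.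

The compounds shown do not separate the amide from the added methylene link, which a benzyl or an acetamidomethyl group in the same place could help to do. They also leave open whether benzamidomethyl gives a similar step with 1,3-benzoxazol-2-yl in place of 1,3-benzothiazol-2-yl on the amine nitrogen in a ring.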